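The compounds below may be only part of what the source reports. "The series", "measured", "known", "first", "only" and "open" are said of these compounds alone.

Measured in an ADME assay on Vero cells (Chlorocebus sabaeus) for cytotoxicity, read by CellTiter-Glo, with a stated time of 72 h; a lower number here means that less compound is tolerated, a higher number that more compound is tolerated:
- Compound 1 `[O-][n+]1nc(N[C@@H]2C[C@H]3CC[C@@H]2C3)[n+]([O-])c2ccc(F)cc21`: < 2.5 ug/mL, a limit
- Compound 2 `[O-][n+]1nc(NC2CCCC2)[n+]([O-])c2ccc(Br)cc21`: 18 ug/mL

Among the measured compounds shown here, compound 2, at 18 ug/mL, holds the only actual number so far, so it is the sole firm reference point. Compound 3 `[O-][n+]1nc(N[C@@H]2C[C@H]3CC[C@@H]2C3)[n+]([O-])c2ccc(Br)cc21` keeps the core of compound 2 and changes one group, on a nitrogen on an aromatic ring: a group of 7 heavy atoms (7 carbon; 2 five-membered non-aromatic rings of carbon only) in place of a group of 5 heavy atoms (5 carbon; one five-membered non-aromatic ring of carbon only), on a nitrogen on an aromatic ring. The entering group also occurs on compound 1, although that compound differs from compound 3 elsewhere in the core. Compound 1 is reported only as a limit, < 2.5 ug/mL. That single reading points towards less compound being tolerated, but it is thin support. In this assay the expected change is a moderate fall, an estimated 2.6-fold lower number from compound 2 to compound 3 (0.41 log units; beyond the scatter). For compound 3 the estimated value is 7 ug/mL, with an expected range from 2.5 ug/mL to 16 ug/mL.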

Compound 3, half-maximal cytotoxic concentration: 0.8 ug/mL
Estimate against measurement, compound 3: 8.8-fold (0.94 log units) above; the whole stated range lies above it.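

In this assay, with bromo kept on the shared core, putting the group of 7 heavy atoms in place of cyclopentyl on a nitrogen on an aromatic ring gives a 23-fold lower number from compound 2 to compound 3 (1.35 log units; beyond the scatter), so far less compound is tolerated. Among the compounds shown here, this is the first readable measure of this change, since the entering group had previously appeared only on compound 1, whose core also differs. Compound 1 is reported only as a limit, so its step to compound 3, bromo in place of fluoro on an aromatic carbon, cannot be read: the limit of < 2.5 ug/mL in this assay, at which 1 of the 3 values shown sits.

The compounds shown do not separate the roles of the second ring and the 3 defined stereocentres of the entering group. On these data alone, how a cyclohexyl ring, an open isopropyl chain or a chain ending in an amine would fare on this nitrogen also remains open.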